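The compounds below may be only part of what the source reports. "The series", "measured", "known", "first", "only" and "open" are said of these compounds alone.

Measured so far in an assay (Cricetulus griseus) for inhibition of aldehyde dehydrogenase, mitochondrial (Homo sapiens); on this read-out higher numbers stand for weaker inhibition and lower numbers for stronger inhibition:
compound 1 `NCCCCCCOc1ccc2c(=O)c(-c3ccc(O)cc3)coc2c1`, 100 nM
compound 2 `CCOC(=O)CCCCCOc1ccc2c(=O)c(-c3ccc(O)cc3)coc2c1`, 280 nM
compound 3 `CCOc1ccc2c(=O)c(-c3ccc(O)cc3)coc2c1`, 80 nM

Compound 3 shows the lowest number of the three in this assay; compound 1 lies within the scatter of it, so no order between those two is drawn, while compound 2 stands clearly apart, the step being a 3.5-fold lower number from compound 2 to compound 3 (0.54 log units; beyond the scatter).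

Compound 4 `CCOC(=O)CCCCOc1ccc2c(=O)c(-c3ccc(O)cc3)coc2c1` differs from compound 3 by 2-(ethoxycarbonyl)ethyl in place of hydrogen on a saturated chain carbon, two bonds along the chain from an oxygen on an aromatic ring. The step that bears most directly on this is the one from the 3-(ethoxycarbonyl)propyl chain of compound 2 to the bare position of compound 3, a 3.5-fold lower number from compound 2 to compound 3 (0.54 log units; beyond the scatter), a modest step; compound 4 carries the shorter 2-(ethoxycarbonyl)ethyl chain, the same kind of change read in the opposite direction. The step of a 2.8-fold higher number from compound 1 to compound 2 (0.45 log units; beyond the scatter), ethoxycarbonyl in place of aminomethyl, was modest as well. A modest rise beyond the scatter is therefore expected for compound 4, a 2.5-fold higher number from compound 3 to compound 4 (0.40 log units; beyond the scatter). The number for compound 4 in this assay is estimated at 200 nM, with a range from 100 nM to 400 nM.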

Compound 4, half-maximal inhibitory concentration: 240 nM
For compound 4 the middle estimate is 1.2-fold (0.08 log units) below the measured one, and the stated range covers the measured number.
By their numbers in this assay, from the lowest: compounds 3 and 1 (each within the scatter of the next); then compounds 4 and 2 (each within the scatter of the next).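

In this assay, 2-(ethoxycarbonyl)ethyl in place of hydrogen on a saturated chain carbon, two bonds along the chain from an oxygen on an aromatic ring, gives (a 3.0-fold higher number from compound 3 to compound 4 (0.48 log units; beyond the scatter)), so an ester-ending chain of this length also separates from the bare position. Chain length between the two esters cannot be resolved (a 1.2-fold lower number from compound 2 to compound 4 (0.07 log units; within the scatter)), and no order is drawn between compound 2 and compound 4. The terminal group now shows up at a second chain length, as the amine of compound 1 and the ester of compound 4 also stand apart (a 2.4-fold higher number from compound 1 to compound 4 (0.38 log units; beyond the scatter)), although those chains differ in more than the end group.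

Nothing shown gives a reason for these steps.

From the compounds shown here alone, whether a carboxylic acid in place of the ethyl ester would stay with compound 2 and compound 4 remains open. So does whether an amine on a shorter chain, or a longer chain with either end group, would stay with compound 1 and compound 3.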